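Trimming the side chain of compound 3

The source may report more compounds than this note shows. Statements on the series, on what has been measured and on what is new or still open speak of the compounds shown alone.

In an ADME assay on MDBK cells (Bos taurus) for cytotoxicity, read by MTT assay, with a stated time of 96 h (a higher number here means that more compound is tolerated, a lower number that less compound is tolerated), compound 1 (`CN(/N=N/c1ccccc1)c1ccccc1`) returns only a limit (> 100000 nM). Compound 2 (`Fc1ccc(F)c(/N=N/Nc2cccc(C(F)(F)F)c2)c1`) also returns only a limit (> 100000 nM). Among the measured compounds shown here, compound 3 (`CN(C)CCCN(/N=N/c1cccc([N+](=O)[O-])c1)c1ccccc1`) gives 37000 nM as the only actual number of the three. Compound 4 (`CN(/N=N/c1cccc([N+](=O)[O-])c1)c1ccccc1`) differs from it in one place (hydrogen in place of 2-(dimethylamino)ethyl on a saturated chain carbon bound to a nitrogen on an aromatic ring): the 3-(dimethylamino)propyl chain of compound 3 becomes methyl. For the measured compounds named here, no measured pair shows this change alone, so only a moderate rise in this assay is expected, meaning more compound tolerated. Compound 1, which lacks that chain, shows the limit of > 100000 nM in this assay, at which 2 of the 3 values shown sit, and is the basis of this expectation. The estimated change is a rise (a 2.3-fold higher number from compound 3 to compound 4 (0.36 log units; beyond the scatter)). For compound 4 the estimated value is 85000 nM with an expected range from 35000 nM to 150000 nM on repeated measurement.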

Compound 4, half-maximal cytotoxic concentration: 82000 nM
For compound 4 the middle estimate is 1.0-fold (0.02 log units) above the measured one, and the stated range covers the measured number.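

In this assay, the side chain now has a measured effect of its own: replacing 3-(dimethylamino)propyl with methyl gives a 2.2-fold higher number from compound 3 to compound 4 (0.35 log units; beyond the scatter). Placing nitro in place of hydrogen on an aromatic carbon gives an at least 1.2-fold lower number from compound 1 to compound 4 (0.08 log units; that floor lies within the scatter), so no effect of the nitro group can be claimed. That step starts from a limit rather than a true number, and such limits are common in this small set: the limit of > 100000 nM in this assay, at which 2 of the 4 values shown sit.

From the compounds shown here alone, it remains open whether a shorter chain, or a chain ending in a carboxylic acid instead of an amine, would behave like methyl or like 3-(dimethylamino)propyl. Going by these compounds, the effect of the chain without the nitro group also remains unknown.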